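From compound 3 to compound 4: one group exchanged

The compounds below may be only part of what the source reports. "The series", "measured", "known", "first", "only" and "open" are said of these compounds alone.

Results in an ADME assay on microsomes from liver (Homo sapiens) for metabolic stability, read by LC-MS, with a stated time of 30 min, tested at 1 uM (on this read-out higher numbers stand for a more stable compound and lower numbers for a less stable compound), for the three measured compounds

compound 1 `Cc1ccccc1S(=O)(=O)c1ccc(CNC(=O)c2cc3cnccc3[nH]2)cc1` gives 48%
compound 2 `O=C(NCc1ccc(S(=O)(=O)c2ccccc2)cc1)c1ccc2ncncc2c1` gives 24%
compound 3 `O=C(NCc1ccc(S(=O)(=O)c2ccccc2)cc1)c1nc2cnccc2[nH]1` gives 73%

Of these three, compound 3 stands highest, and the gaps down to compound 1 and to compound 2 both lie beyond the scatter. The next compound to be tested is compound 4 `O=C(NCc1ccc(S(=O)(=O)c2ccccc2)cc1)c1cc2ccncc2s1`, which differs from compound 3 in a single group on a carbonyl carbon (a group of 9 heavy atoms (7 carbon, 1 nitrogen, 1 sulfur; one five-membered aromatic ring with 1 hetero atom, one six-membered aromatic ring with 1 hetero atom) in place of a group of 9 heavy atoms (6 carbon, 3 nitrogen; one five-membered aromatic ring with 2 hetero atoms, one six-membered aromatic ring with 1 hetero atom), on a carbonyl carbon). Among the compounds with values here, no pair of measured compounds shows this exchange, so the data give no direct guide to its effect. The expectation rests only on the spread of values. Compound 3 (73%) sits at the top of that spread, while compound 1 (48%) and compound 2 (24%) lie well under it, so a fall seems more likely than a rise. The expected change in this assay is a decrease beyond the scatter, estimated as a number 33 percentage points lower from compound 3 to compound 4 (beyond the scatter), though with wide uncertainty. For compound 4 the expected value is 40% with an estimated range (18% to 65%).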

Compound 4, percent of the compound remaining: 48%
Beside the measured number, compound 4's estimate is 8 percentage points below it; measured number inside the range.
By their numbers in this assay, from the lowest: compound 2; then compounds 1 and 4 (each within the scatter of the next); then compound 3.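

In this assay, within the data shown here, the exchange on the carbonyl carbon gives a number 25 percentage points lower from compound 3 to compound 4 (beyond the scatter), the first reading of a single change in this set, with the rest of the molecule held constant. It shows that the outcome at this place depends on the group attached: the group that leaves has a five-membered aromatic ring with 2 hetero atoms and 1 hydrogen-bond donor, while the group that enters has a five-membered aromatic ring with 1 hetero atom and 0 hydrogen-bond donors. Nothing measured here bears on why the number falls.

The ring atoms and the donor count change together in this one step, so the compounds shown cannot separate their contributions. Going by these compounds, it also remains open how compound 3 would read in this assay with a methyl group on the nitrogen of its five-membered ring.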